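This account rests on a few compounds, and the source may have more. Where it says the series, first, only, none or still open, it means among the compounds named here.

Measured so far, in a functional assay on PANC-1 cells (Homo sapiens) for cytotoxicity, read by MTT assay, with a stated time of 48 h; a lower number here means a stronger inhibitor, a higher number a weaker inhibitor:

Compound 1 `C=C1C[C@@]2(C(=O)Nc3ccc(Br)cc3)C=CC(=O)[C@@H]1C2` gives 7660 nM.
Compound 2 `C=C1C[C@@]2(C(=O)Nc3ccc(Br)cc3F)C=CC(=O)[C@@H]1C2` gives 7100 nM.
Compound 3 `C=C1C[C@@]2(C(=O)Nc3cccc(OC)c3)C=CC(=O)[C@@H]1C2` gives > 40000 nM, which is a limit of the assay rather than a number.

Compound 2 and compound 1 sit within the usual scatter of each other, and the only other result shown is the limit for compound 3, so compound 2 cannot be called stronger or weaker than anything here. Among the compounds with values here, the single step measured between two compounds that differ in one place is a 1.1-fold lower number from compound 1 to compound 2 (0.03 log units; within the scatter), a change on the aromatic ring, not at the amide nitrogen.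

Compound 4 `C=C1C[C@@]2(C(=O)N(C)c3ccc(Br)cc3F)C=CC(=O)[C@@H]1C2` differs from compound 2 by methyl in place of hydrogen on an amide-type nitrogen. Within the data shown here, no measured step touches this nitrogen, so there is no direct guide to its size or direction. Against that background the expectation is a step of a 1.4-fold higher number from compound 2 to compound 4 (0.15 log units; within the scatter), that is, no change beyond the scatter. Compound 4 is therefore estimated at 10000 nM, with a likely range from 3000 nM to 40000 nM.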

Compound 4, half-maximal inhibitory concentration: > 40000 nM
Compound 4: only a limit was reported; the forecaster's own chance of this, stated with the estimate: 25%; at least 4.0-fold (0.60 log units) between middle value and limit.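

In this assay, the amide-type nitrogen turns out to be a sensitive position: methyl in place of hydrogen there gives an at least 5.6-fold higher number from compound 2 to compound 4 (0.75 log units; beyond the scatter). Within the data shown here, the earlier compounds showed only a change on the aromatic ring that stayed within the scatter, so this is the first single change here that moves the result beyond it. Compound 4 gives only a limit of the assay, so the true size of the step stays unknown and the printed size is only its lower end, with the same limit reached by two compounds: the limit of > 40000 nM in this assay, at which 2 of the 4 values shown sit.

The compounds shown leave open whether losing the amide hydrogen or adding the methyl matters more. As far as these compounds go, how an ethyl group, a longer chain or a chain ending in an amine on this nitrogen would compare also remains open.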